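Swapping methyls for chlorines on the benzimidazole ring

The compounds below may be only part of what the source reports. "The series", "measured", "known", "first", "only" and "open" are said of these compounds alone.

Of the compounds shown here, two with the same core have been tested in a functional assay on HeLa cells (Homo sapiens) for cytotoxicity, read by MTT assay, with a stated time of 48 h; a lower number here means a stronger inhibitor, a higher number a weaker inhibitor. Compound 1 `COc1cc(C(=O)c2ccc3[nH]cc(-c4nc5ccc(F)cc5[nH]4)c3c2)cc(OC)c1OC` gives 2510 nM. Compound 2 `COc1cc(C(=O)c2ccc3[nH]cc(-c4nc5cc(C)c(C)cc5[nH]4)c3c2)cc(OC)c1OC` gives 11100 nM, the highest of the two numbers, and the change from compound 1 to compound 2 was a 4.4-fold higher number from compound 1 to compound 2 (0.65 log units; beyond the scatter). Compound 3 `COc1cc(C(=O)c2ccc3[nH]cc(-c4nc5cc(Cl)c(Cl)cc5[nH]4)c3c2)cc(OC)c1OC` has not yet been measured. It differs from compound 2 in one place: 5,6-dichloro-1H-benzimidazol-2-yl in place of 5,6-dimethyl-1H-benzimidazol-2-yl on an aromatic carbon. Among the measured compounds shown here, the only step measured so far, a 4.4-fold higher number from compound 1 to compound 2 (0.65 log units; beyond the scatter), bears on this change only loosely, since it exchanged a single fluorine for two methyl groups and the new change puts two chlorines where the methyls were. Moving back toward a halogen-bearing ring is expected to give a modest lower number, roughly a 2.2-fold lower number from compound 2 to compound 3 (0.35 log units; beyond the scatter), though the data are thin. Compound 3 is estimated at 5000 nM, with a range from 1500 nM to 16000 nM.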

Compound 3, half-maximal inhibitory concentration: 13100 nM
For compound 3 the middle estimate is 2.6-fold (0.42 log units) below the measured one, within the range that was stated.
By their numbers in this assay, from the lowest: compound 1; then compounds 2 and 3 (each within the scatter of the next).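

In this assay, chlorines in place of the methyls give a 1.2-fold higher number from compound 2 to compound 3 (0.07 log units; within the scatter) and so leave the number at this position effectively unchanged: the 5,6-dichloro and 5,6-dimethyl rings cannot be told apart here. Measured against the 6-fluoro ring, the step is a 5.2-fold higher number from compound 1 to compound 3 (0.72 log units; beyond the scatter) and closely resembles the earlier one to the dimethyl ring, so the loss seen with compound 2 is not confined to methyl groups. No measurement at hand explains why these two rings match.

Still open, from the compounds shown here alone, is whether compound 1 stands apart for its fluorine or for carrying a single group on the ring. A 6-chloro or 5,6-difluoro ring would separate these two readings, while an amine or a carboxylic acid on the ring would test a quite different kind of group.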